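The compounds below may be only part of what the source reports. "The series", "measured", "known", "first", "only" and "open" are said of these compounds alone.

Measured so far in a functional assay on MCF7 cells (Homo sapiens) for cytotoxicity, read by sulforhodamine B assay, with a stated time of 3 days; on this read-out lower numbers stand for stronger inhibition and higher numbers for weaker inhibition:
- compound 1 `Cc1cn(C2CN(S(=O)(=O)c3ccccc3[N+](=O)[O-])c3ccccc3CO2)c(=O)[nH]c1=O`: 45200 nM
- compound 2 `Nc1ccccc1S(=O)(=O)N1CC(n2cnc3c(Cl)nc(Cl)nc32)OCc2ccccc21`: 820 nM
- compound 3 `O=[N+]([O-])c1ccccc1S(=O)(=O)N1CC(n2cnc3c(Cl)nc(Cl)nc32)OCc2ccccc21`: 383 nM

Compound 3 has the lowest number of the three, with compound 2 nearest and compound 1 furthest. The next compound is compound 4 `O=[N+]([O-])c1ccccc1S(=O)(=O)N1CC(n2cnc3c(Br)ncnc32)OCc2ccccc21`. The change is a group of 10 heavy atoms (5 carbon, 4 nitrogen, 1 bromine; one five-membered aromatic ring with 2 hetero atoms, one six-membered aromatic ring with 2 hetero atoms) in place of a group of 11 heavy atoms (5 carbon, 4 nitrogen, 2 chlorine; one five-membered aromatic ring with 2 hetero atoms, one six-membered aromatic ring with 2 hetero atoms), on a saturated ring carbon, on a saturated ring carbon next to the ring oxygen.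

Among the compounds with values here, two measured steps bear on this. An exchange at the same carbon gave a 120-fold lower number from compound 1 to compound 3 (2.07 log units; beyond the scatter), so this assay has responded strongly to a change there. However, that exchange altered the aromatic ring count, whereas the present one does not. The other step, a 2.1-fold lower number from compound 2 to compound 3 (0.33 log units; beyond the scatter), lies at a different place and only gives a scale for a small edit. Within the data shown here, no measured step isolates the present exchange, so its direction is poorly supported.

A modest move towards a higher number is expected, namely a 1.8-fold higher number from compound 3 to compound 4 (0.26 log units; within the scatter). For compound 4 the estimated value is 700 nM, with an expected range of 250 nM to 2500 nM.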

Compound 4, half-maximal inhibitory concentration: 3620 nM
For compound 4 the middle estimate is 5.2-fold (0.71 log units) below the measured one; the measured number lies above the stated range.
By their numbers in this assay, from the lowest: compound 3; then compound 2; then compound 4; then compound 1.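

In this assay this position responds even when the aromatic ring count stays the same: a 9.5-fold higher number from compound 3 to compound 4 (0.98 log units; beyond the scatter), so the two-ring groups cannot be treated as interchangeable here. The group of 10 heavy atoms (5 carbon, 4 nitrogen, 1 bromine) keeps only part of the advantage over the single-ring group of compound 1, as a 12-fold lower number from compound 1 to compound 4 (1.10 log units; beyond the scatter) stands against a 120-fold lower number from compound 1 to compound 3 (2.07 log units; beyond the scatter), both steps lying on the same saturated ring carbon. No measurement to hand explains the size of the new step.

The step removes 2 chlorine and brings in 1 bromine in a single edit, and the compounds shown do not separate the loss of a chlorine from the arrival of the bromine. Also open, from the compounds shown here alone, is how an amine in place of the bromine would compare on this group.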